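From propanoyl to (1H-pyrazol-3-yl)carbonyl on compound 1

The compounds below may be only part of what the source reports. "The series", "measured", "known", "first", "only" and "open" are said of these compounds alone.

Among the measured compounds shown here, in an ADME assay on microsomes (Rattus norvegicus) for metabolic stability (a lower number here means that the compound disappears faster, a higher number that the compound lasts longer), only two compounds have numbers so far. Compound 1 (`CCC(=O)N1CCC(C(=O)N2N=CCC2c2ccccc2)CC1`) gives 1.07 h, and compound 2 (`CC(C)(C)C(=O)N1N=CCC1c1cccc(Cl)c1`) gives 0.05 h. Compound 1 thus holds the higher of the two numbers, and the gap between them lies beyond the usual scatter. For the measured compounds named here, these two compounds do not form a pair that differs in one place, so no measured step is available as a guide.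

Compound 3 (`O=C(c1cc[nH]n1)N1CCC(C(=O)N2N=CCC2c2ccccc2)CC1`) has not yet been measured. It keeps the core of compound 1 but carries 1H-pyrazol-3-yl in place of ethyl on a carbonyl carbon whose other neighbours are an amide-type nitrogen in a ring: 1H-pyrazol-3-yl in place of ethyl on a carbonyl carbon. The expectation therefore rests only on this change and on compound 1 at 1.07 h. No step beyond the scatter is expected in this assay, in either direction. The expected change is small, a 1.3-fold lower number from compound 1 to compound 3 (0.13 log units; within the scatter). For compound 3 the estimated half-life is 0.8 h, with an expected range from 0.3 h to 2.5 h.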

Compound 3, half-life: 0.317 h
Estimate against measurement, compound 3: 2.5-fold (0.40 log units) above; low and high end bracket the measured number.
By their numbers in this assay, from the lowest: compound 2; then compound 3; then compound 1.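

In this assay, the carbonyl carbon that carries ethyl in compound 1 proves sensitive to what is attached there: 1H-pyrazol-3-yl in place of ethyl gives a 3.4-fold lower number from compound 1 to compound 3 (0.53 log units; beyond the scatter). The step is modest but beyond the usual scatter, so the shared core does not by itself fix the half-life, and this one change is enough to shift it. No measurement available here bears on the reason for this step.

The change swaps a small open chain for a five-membered aromatic ring and adds two nitrogen atoms, a hydrogen-bond donor and a hydrogen-bond acceptor all at once, so the compounds shown leave open which of these features goes with the lower number. From the compounds shown here alone, it also remains open whether a phenyl ring, which has no ring nitrogen, or a longer chain such as butyl on the same carbonyl carbon would give a half-life closer to that of compound 1 or to that of compound 3.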